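Fluorophenyl Replaces the Cyclopropylethynyl Arm on the Core

The compounds below may be only part of what the source reports. "The series", "measured", "known", "first", "only" and "open" are said of these compounds alone.

Compound 1, `Nc1ncnn2c([C@@H]3O[C@H](CO)[C@@H](O)[C@H]3O)cc(C#CC3CC3)c12`, gives 40 nM in a functional assay on HL-60 cells (Homo sapiens) for antiproliferative activity, with a stated time of 72 h; a lower number here means a stronger inhibitor, a higher number a weaker inhibitor.
Compound 2, `Nc1ncnn2c([C@@H]3O[C@H](CO)[C@@H](O)[C@H]3O)cc(C#Cc3ccccc3)c12`, gives > 100000 nM in this assay, which is a limit of the assay.
Compound 3, `Nc1ncnn2c([C@@H]3O[C@H](CO)[C@@H](O)[C@H]3O)cc(-c3ccccc3)c12`, gives > 100000 nM in this assay, again a limit of the assay.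

For the measured compounds named here, compound 1 therefore stands alone as the only compound with a number in this assay; the other two sit at the limit of > 100000 nM in this assay, at which 2 of the 3 values shown sit. The step from compound 1 to compound 2 is an at least 2500-fold higher number from compound 1 to compound 2 (3.39 log units; beyond the scatter), and from compound 1 to compound 3 it is an at least 2500-fold higher number from compound 1 to compound 3 (3.39 log units; beyond the scatter). Between compound 2 and compound 3 the step is a step that the two limits leave unreadable from compound 2 to compound 3.

Compound 4, `Nc1ncnn2c([C@@H]3O[C@H](CO)[C@@H](O)[C@H]3O)cc(-c3ccc(F)cc3)c12`, differs from compound 1 as follows: 4-fluorophenyl in place of 2-cyclopropylethynyl on an aromatic carbon. Both measured steps from compound 1 bear on this change. Exchanging cyclopropyl for phenyl on the triple-bonded carbon, or exchanging the whole 2-cyclopropylethynyl arm for phenyl on the aromatic carbon, each moved the value to the assay limit. Compound 4 carries an aryl ring on that same aromatic carbon, as compound 3 does, now bearing a fluorine. A large rise in the number is thus expected, a 2500-fold higher number from compound 1 to compound 4 (3.40 log units; beyond the scatter). Compound 4 is estimated at 100000 nM, within a range from 20000 nM to 400000 nM, and is likely to be reported only as a limit.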

Compound 4, half-maximal inhibitory concentration: 68300 nM
Beside the measured number, compound 4's estimate is 1.5-fold (0.17 log units) above it; the measured number falls inside the stated range.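

The loss on going from the 2-cyclopropylethynyl arm to an aryl ring on this aromatic carbon now has a readable size in this assay, a 1700-fold higher number from compound 1 to compound 4 (3.23 log units; beyond the scatter). The fluoro group on the phenyl ring gives only a floor, an at least 1.4-fold lower number from compound 3 to compound 4 (0.16 log units; that floor lies within the scatter), and the exchange of the 2-phenylethynyl arm for 4-fluorophenyl gives another, an at least 1.4-fold lower number from compound 2 to compound 4 (0.16 log units; that floor lies within the scatter), so neither shows a change beyond the scatter. Compound 2 and compound 3 stay at a limit of the assay: the limit of > 100000 nM in this assay, at which 2 of the 4 values shown sit.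

Going by these compounds, the step between compound 2 and compound 3 cannot be read, so the role of the triple bond in an arm that ends in phenyl stays open. Also open, on these data alone, is whether the activity of compound 1 depends on the cyclopropyl ring itself or would survive with a methyl or a tert-butyl group on the triple-bonded carbon, and whether an amine in place of the fluorine of compound 4 would move its number.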